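One Stereocentre Flipped on a Measured Half-Life

The source may report more compounds than this note shows. Statements on the series, on what has been measured and on what is new or still open speak of the compounds shown alone.

Measured so far in an ADME assay on microsomes from liver (Homo sapiens) for metabolic stability; a lower number here means that the compound disappears faster, a higher number that the compound lasts longer:
Compound 1 `CCC(/C=C1\OC(=O)NC1=O)(CC)c1ccc(-c2ccc3cc(F)cc(F)c3c2)[nH]c1=O` gives > 3 h as a limit of the assay
Compound 2 `CC(C)[C@H](C[C@H]1OC(=O)NC1=O)c1ccc(-c2ccc3cccc(F)c3c2)[nH]c1=O` gives 1.68 h as a number

Among the compounds with values here, compound 2 holds the only actual number in this assay at 1.68 h as its half-life. Compound 1 stands at > 3 h which is a limit and not a number. Compound 3 `CC(C)[C@H](C[C@@H]1OC(=O)NC1=O)c1ccc(-c2ccc3cccc(F)c3c2)[nH]c1=O` keeps the atoms and bonds of compound 2 and changes in configuration only (the two compounds have the same atoms and bonds and differ only in configuration as drawn: 1 of 2 stereo elements differ; a stereocentre at a saturated ring carbon is drawn R in compound 2 and S in compound 3). Within the data shown here, no measured pair shows what such a change does. The expected change a 1.0-fold higher number from compound 2 to compound 3 (0.01 log units; within the scatter) stays within the usual scatter, with no direction foreseen. In this assay compound 3 is estimated at 1.7 h with an expected range from 0.9 h to 3 h for its half-life.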

Compound 3, half-life: 2.07 h
For compound 3 the middle estimate is 1.2-fold (0.09 log units) below the measured one; low and high end bracket the measured number.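

In this assay the stereocentre at a saturated ring carbon now has a measured pair, and the step reads a 1.2-fold higher number from compound 2 to compound 3 (0.09 log units; within the scatter). Within the data shown here, at this position, with the rest of the structure held fixed, the drawn configuration leaves the half-life within the usual scatter, something no earlier pair could show. The comparison rests on this single change: the fact that compounds 2 and 3 differ only in the configuration as drawn

Among these compounds, the other stereo element, which the two compounds share, has no measured pair of its own. Nor do the compounds shown tell what an amine or a carboxylic acid on the shared core would do to the half-life.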